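The compounds below may be only part of what the source reports. "The series", "measured", "known", "first", "only" and "open" are said of these compounds alone.

Values in a functional assay on OVCAR-3 cells (Homo sapiens) for inhibition, read by sulforhodamine B assay, with a stated time of 48 h; a lower number here means a stronger inhibitor of growth, a higher number a weaker inhibitor of growth:
Compound 1, `CC1=CC[C@H](C(C)(C)NC(=S)N/N=C/c2ccccc2O)CC1`: 5500 nM.
Compound 2, `CC1=CC[C@H](C(C)(C)NC(=S)N/N=C/c2ccc(F)cc2)CC1`: > 100000 nM, a limit of the assay.
Compound 3, `CC1=CC[C@H](C(C)(C)NC(=S)N/N=C/c2ccccc2Cl)CC1`: 15100 nM.

Compound 3 holds the highest of the two numbers; the nearest is compound 1, and the step of a 2.7-fold higher number from compound 1 to compound 3 (0.44 log units; beyond the scatter) is modest. Compound 4, `CC1=CC[C@H](C(C)(C)NC(=S)N/N=C/c2ccc(Cl)cc2)CC1`, is not yet measured and differs from compound 3 by 4-chlorophenyl in place of 2-chlorophenyl on a carbon with a double bond to nitrogen. Among the compounds with values here, no measured step exchanges 2-chlorophenyl for 4-chlorophenyl directly. Within the data shown here, the steps that bear on it are an at least 6.6-fold lower number from compound 2 to compound 3 (0.82 log units; beyond the scatter) and an at least 18-fold higher number from compound 1 to compound 2 (1.25 log units; beyond the scatter); in both the 4-fluorophenyl compound carries the higher number. Compound 2 sits at the limit of > 100000 nM in this assay, at which 1 of the 3 values shown sits. On this basis a move from 2-chlorophenyl to 4-chlorophenyl is expected to raise the number in this assay, by a step of a 3.3-fold higher number from compound 3 to compound 4 (0.52 log units; beyond the scatter), with real uncertainty since the measured comparisons involve 4-fluorophenyl rather than 4-chlorophenyl. Compound 4 is estimated at 50000 nM, within a range of 15000 nM to 150000 nM, and a limit rather than a number is a fair possibility.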

Compound 4, concentration for 50% growth inhibition: 8600 nM
For compound 4 the middle estimate is 5.8-fold (0.76 log units) above the measured one; measured number below the stated range.
By their numbers in this assay, from the lowest: compounds 1, 4 and 3 (each within the scatter of the next, the first and the last beyond it). At a limit, above all of these: compound 2.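

In this assay, 4-chlorophenyl on the carbon with a double bond to nitrogen is not separated from 2-chlorophenyl (a 1.8-fold lower number from compound 3 to compound 4 (0.24 log units; within the scatter)) or from 2-hydroxyphenyl (a 1.6-fold higher number from compound 1 to compound 4 (0.19 log units; within the scatter)), although compounds 1 and 3 do stand apart from each other (a 2.7-fold higher number from compound 1 to compound 3 (0.44 log units; beyond the scatter)). The halogen matters among the two compounds with a halogen in this printed form, as chloro in place of fluoro on an aromatic carbon gives a large step (an at least 11-fold lower number from compound 2 to compound 4 (1.06 log units; beyond the scatter)), so the loss seen with compound 2 cannot be read as belonging to every group of this kind. Compound 2 remains a limit of the assay: (the limit of > 100000 nM in this assay, at which 1 of the 4 values shown sits).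

The compounds shown leave open whether the large step is particular to fluoro or also extends to other groups on the phenyl ring. An amine, a methoxy group or a carboxylic acid in that place could test this.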